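A few compounds are considered here, and "the series" means these few. Any claim that something is new, unique, unknown or untested is made for them only; others in the source may bear on it.

In a functional assay on MCF7 cells (Homo sapiens) for antiproliferative activity, read by MTT assay, with a stated time of 72 h (on this read-out lower numbers stand for stronger inhibition and higher numbers for weaker inhibition), compound 1 `O=S(=O)(Oc1ccc(Br)cc1)C1CC2OC1C(c1ccc(/C=C/c3cc(O)cc(O)c3)cc1)=C2c1ccc(O)cc1` gives 16900 nM, compound 2 `O=S(=O)(Oc1ccc(Cl)cc1)C1CC2OC1C(c1ccc(/C=C/c3cc(O)cc(O)c3)cc1)=C2c1ccc(O)cc1` gives 17900 nM and compound 3 `O=S(=O)(Oc1ccccc1C(F)(F)F)C1CC2OC1C(c1ccc(/C=C/c3cc(O)cc(O)c3)cc1)=C2c1ccc(O)cc1` gives 18300 nM, so compound 3 stands level with the other two within the scatter. Compound 4 `O=S(=O)(Oc1cccc(C(F)(F)F)c1)C1CC2OC1C(c1ccc(/C=C/c3cc(O)cc(O)c3)cc1)=C2c1ccc(O)cc1` differs from compound 3 in one place: 3-(trifluoromethyl)phenyl in place of 2-(trifluoromethyl)phenyl on an oxygen. Among the measured compounds shown here, no measured compound carries the 3-(trifluoromethyl)phenyl group. The nearest evidence is a 1.0-fold higher number from compound 2 to compound 3 (0.01 log units; within the scatter) and a 1.1-fold higher number from compound 1 to compound 3 (0.03 log units; within the scatter), two exchanges of the group on that same oxygen, and both stay within the scatter. In this assay, no step beyond the scatter is therefore expected, and no direction is favoured. The expected change is a 1.0-fold lower number from compound 3 to compound 4 (0.01 log units; within the scatter). For compound 4 the estimated value is 18000 nM, with an expected range of 11000 nM to 30000 nM.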

Compound 4, half-maximal inhibitory concentration: 11500 nM
Beside the measured number, compound 4's estimate is 1.6-fold (0.19 log units) above it; the measured number falls inside the stated range.
By their numbers in this assay, from the lowest: compounds 4, 1, 2 and 3 (each within the scatter of the next).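

In this assay, the exchange of 2-(trifluoromethyl)phenyl for 3-(trifluoromethyl)phenyl on the oxygen gives a 1.6-fold lower number from compound 3 to compound 4 (0.20 log units; within the scatter), so the two trifluoromethyl isomers cannot be told apart at this position. The steps from the halogenated groups read the same, with a 1.6-fold lower number from compound 2 to compound 4 (0.19 log units; within the scatter) and a 1.5-fold lower number from compound 1 to compound 4 (0.17 log units; within the scatter), and all four groups on this oxygen stand level. Nothing further is available to account for these values. Going by these compounds, whether an amine or a carboxylic acid on that phenyl ring would give a step beyond the scatter remains open.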